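This account rests on a few compounds, and the source may have more. Where it says the series, first, only, none or still open, it means among the compounds named here.

Compound 1 `C(#Cc1nc2c(s1)CN(C1CCCCC1)CC2)c1ccccc1` gives > 10000 nM in an assay on HEK293 cells for negative allosteric modulation of metabotropic glutamate receptor 5 (Homo sapiens), read by FLIPR, with a stated time of 1 h (a higher number here means a weaker inhibitor, a lower number a stronger inhibitor), a limit of the assay.
Compound 2 `CC1CC(C(=O)N2CCc3nc(C#Cc4ccccc4)sc3C2)C1` gives > 10000 nM in this assay, also a limit.
Compound 3 `O=C(c1cccc(Cl)c1)N1CCc2nc(C#Cc3ccccc3)sc2C1` gives > 10000 nM in this assay, again a limit.

Compound 2 thus stands at the limit of > 10000 nM in this assay, at which 3 of the 3 values shown sit, together with the other two. The next compound, compound 4 `O=S(=O)(C1CC1)N1CCc2nc(C#Cc3ccccc3)sc2C1`, differs from compound 2 in one place: cyclopropylsulfonyl in place of (3-methylcyclobutyl)carbonyl on an amine nitrogen in a ring. For the measured compounds named here, two measured steps touch the same nitrogen of the shared core: a step that the two limits leave unreadable from compound 1 to compound 2 and a step that the two limits leave unreadable from compound 2 to compound 3. Neither is readable; both ends of each sit at the limit. Going by the values given here, no measured step therefore fixes a size or direction for the change to compound 4 in this assay; the three values only show that none of the groups tried on this nitrogen reached the measurable range. Compound 4 is expected at 15000 nM, range 3000 nM to 60000 nM, an expected step that the limit leaves unreadable from compound 2 to compound 4, most probably reported once more as a limit.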

Compound 4, half-maximal inhibitory concentration: 34 nM
Beside the measured number, compound 4's estimate is 440-fold (2.64 log units) above it; the whole stated range lies above it.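

In this assay, the amine nitrogen in the ring proves able to give a readable value: cyclopropylsulfonyl brings an at least 290-fold lower number from compound 2 to compound 4 (2.46 log units; beyond the scatter), and in place of cyclohexyl it brings an at least 290-fold lower number from compound 1 to compound 4 (2.46 log units; beyond the scatter). The steps among compound 1, compound 2 and compound 3 cannot be read. Among the groups shown on this nitrogen, only cyclopropylsulfonyl leaves the limit: the limit of > 10000 nM in this assay, at which 3 of the 4 values shown sit.

The compounds shown leave open whether the sulfonyl or the cyclopropyl ring carries this step. A cyclopropylcarbonyl or a methylsulfonyl group on the same nitrogen would separate the two.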